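The compounds below may be only part of what the source reports. "The series", "measured", "known", "first", "only" and "open" are said of these compounds alone.

Measured in a functional assay, with a stated time of 30 min; a lower number here means a stronger inhibitor, a higher number a weaker inhibitor:
compound 1 `CCCCc1oc2ccc(/N=C/c3ccc(O)cc3)cc2c1C(=O)c1ccc(OC)cc1`: 22.8 ug/mL
compound 2 `CCCCc1oc2ccc(/N=C/c3ccc(Cl)cc3)cc2c1C(=O)c1ccc(OC)cc1`: 75.9 ug/mL
compound 3 `CCCCc1oc2ccc(/N=C/c3ccccc3)cc2c1C(=O)c1ccc(OC)cc1`: 34.2 ug/mL

Among the compounds with values here, only one of the two steps away from compound 1 clears the scatter: a 3.3-fold higher number from compound 1 to compound 2 (0.52 log units; beyond the scatter). The other, a 1.5-fold higher number from compound 1 to compound 3 (0.18 log units; within the scatter), does not, so compound 1 and compound 3 sit together at the low end of these three numbers.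

Compound 4 `CCCCc1oc2ccc(/N=C/c3ccc(Cl)cc3Cl)cc2c1C(=O)c1ccc(OC)cc1` carries the change (2,4-dichlorophenyl in place of 4-hydroxyphenyl on a carbon with a double bond to nitrogen), in words 2,4-dichlorophenyl in place of 4-hydroxyphenyl on a carbon with a double bond to nitrogen. Within the data shown here, the closest measured precedent is the modest step to the single chloro compound, and a 2.2-fold lower number from compound 2 to compound 3 (0.35 log units; beyond the scatter) shows the same gap from the other side. Among the measured compounds shown here, no measured compound carries a second chlorine, so its contribution is unknown and the range must stay wide. A modest step towards a higher number, similar in size to the step to compound 2, is therefore expected. The estimate amounts to a 3.5-fold higher number from compound 1 to compound 4 (0.55 log units; beyond the scatter). Compound 4 is expected at 80 ug/mL, within a range of 35 ug/mL to 170 ug/mL.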

Compound 4, half-maximal inhibitory concentration: 2.44 ug/mL
Estimate against measurement, compound 4: 33-fold (1.52 log units) above; the whole stated range lies above it.
By their numbers in this assay, from the lowest: compound 4; then compounds 1 and 3 (each within the scatter of the next); then compound 2.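

In this assay the 2,4-dichlorophenyl group on the carbon with a double bond to nitrogen stands apart from the other three compounds, with a 9.3-fold lower number from compound 1 to compound 4 (0.97 log units; beyond the scatter) and a 14-fold lower number from compound 3 to compound 4 (1.15 log units; beyond the scatter) showing that this position allows a much lower number than the hydroxy, hydrogen and single chloro compounds had revealed. Within the data shown here, the sharpest contrast is a 31-fold lower number from compound 2 to compound 4 (1.49 log units; beyond the scatter), where the only change is the addition of a second chlorine. Hydrogen in place of chloro gave a 2.2-fold lower number from compound 2 to compound 3 (0.35 log units; beyond the scatter) and so had pointed the other way, which means the same kind of swap can move the number in either direction within this ring.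

Nothing given here accounts for that reversal. The compounds shown leave open whether the 2-chlorophenyl group alone would match compound 4, and whether a 2,4-difluorophenyl or 2,4-dimethylphenyl group would do the same.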